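Nitrooxyalkyl esters: cytotoxicity notes on the series

This account rests on a few compounds, and the source may have more. Where it says the series, first, only, none or still open, it means among the compounds named here.

The three measured compounds share one core, shown for compound 1 as `COc1cc(/C=C/C(=O)OCCCO[N+](=O)[O-])ccc1OCCCO[N+](=O)[O-]`, which carries 3-(nitrooxy)propyl groups on both ester and phenol oxygens. In a functional assay on SKBR cells (Homo sapiens) for cytotoxicity, read by resazurin assay, with a stated time of 72 h (on this read-out lower numbers stand for stronger inhibition and higher numbers for weaker inhibition), compound 1 reports a limit of > 50000 nM and no number. Compound 2, `COc1cc(/C=C/C(=O)OCCCCCO[N+](=O)[O-])ccc1O`, keeps the free phenol and bears a 5-(nitrooxy)pentyl ester; in this assay compound 2 gives 8060 nM. Compound 3, `COc1cc(/C=C/C(=O)OC(C)C)ccc1O`, is the isopropyl ester with the free phenol. In this assay compound 3 reports only a limit, > 50000 nM, so where it stands relative to the others cannot be fixed from the numbers. Two of the three values shown are such limits (the limit of > 50000 nM in this assay, at which 2 of the 3 values shown sit). Among the measured compounds shown here, no measured pair differs in a single place, so no measured step is available.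

Compound 4, `COc1cc(/C=C/C(=O)OCCCO[N+](=O)[O-])ccc1O`, is not yet measured in this assay. It differs from compound 3 in one place (3-(nitrooxy)propyl in place of isopropyl on an oxygen next to a carbonyl group). For the measured compounds named here, the only numeric value in the set comes from compound 2, whose nitrooxy-bearing ester gives 8060 nM. On that basis the step of an at least 3.3-fold lower number from compound 3 to compound 4 (0.52 log units; beyond the scatter) is expected to run toward stronger inhibition, beyond the usual scatter. Compound 4 is estimated at 15000 nM, with a range from 5000 nM to 50000 nM.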

Compound 4, half-maximal inhibitory concentration: 17200 nM
Compound 4: middle estimate off by 1.1-fold (0.06 log units), on the low side, and the stated range covers the measured number.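

In this assay, 3-(nitrooxy)propyl in place of isopropyl on an oxygen next to a carbonyl group gives an at least 2.9-fold lower number from compound 3 to compound 4 (0.46 log units; beyond the scatter), the first measured single-place step at this ester position, and it runs toward stronger inhibition; its full size stays open because the starting compound sits at a limit: the limit of > 50000 nM in this assay, at which 2 of the 4 values shown sit.

Along the same ester chain, the change from 5-(nitrooxy)pentyl to 3-(nitrooxy)propyl gives a 2.1-fold higher number from compound 2 to compound 4 (0.33 log units; beyond the scatter), a modest move toward weaker inhibition, so chain length at this position registers in the read-out. Hydrogen in place of 3-(nitrooxy)propyl on an oxygen on an aromatic ring gives an at least 2.9-fold lower number from compound 1 to compound 4 (0.46 log units; beyond the scatter), so the free phenol form reads on the scale, although this step too is only a bound.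

The chain-length reading rests on a single pair of nitrooxy esters, and a longer nitrooxyalkyl chain would show whether the direction holds. A plain pentyl ester with no nitrooxy group would separate the effect of chain length from that of the nitrooxy group itself.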